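The source may hold more compounds than are shown below. What is called first, only, known or untested is meant among the compounds shown, and "the series" means these compounds.

The series begins with compound 1 `CCCCCCNc1cnc(C(=O)NCc2ccccc2)cn1`, which carries a hexylamino group on a shared core. In an ADME assay on HEL cells (Homo sapiens) for cytotoxicity, read by microscopy, with a stated time of 6 days (on this read-out lower numbers stand for higher toxicity in this test and higher numbers for lower toxicity in this test), compound 1 gives > 100000 nM, and this is a limit of the assay rather than a number. Compound 2 `O=C(NCc1ccccc1)c1cncc(Cl)n1` is a smaller relative that bears a chloro group in place of that chain; in this assay compound 2 gives "not determined" (no result reported), so no number for it is known. Among the values shown, compound 2 therefore stands nowhere, and the only footing in this assay is the limit of > 100000 nM in this assay, at which 1 of the 2 values shown sits, where compound 1 sits. The step to compound 3 `CCCCCCNc1cncc(C(=O)NCc2ccccc2)n1` replaces the chloro group (hexylamino in place of chloro on an aromatic carbon). Compound 3 thus carries the same groups as compound 1, arranged differently on the core. Among the compounds with values here, no measured step joins compound 2 to compound 3, so the size of the change cannot be read from the data. Since compound 1 sits at the limit of > 100000 nM in this assay, at which 1 of the 2 values shown sits, compound 3 is expected to show the same lack of toxicity within the tested range. For compound 3 the estimated value is 100000 nM, with an expected range from 30000 nM to 300000 nM.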

Compound 3, minimum cytotoxic concentration: > 100000 nM
Compound 3: no number, only a limit (the forecaster's own chance of this, stated with the estimate: 85%); the middle value lies on the limit itself.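

No new step can be read from compound 2 to compound 3: compound 2 has no reported number, and compound 3 gives only a limit of the assay. The compounds shown leave open whether moving the hexylamino group on the shared core changes toxicity, as the measured results rest on a single value: the limit of > 100000 nM in this assay, at which 2 of the 3 values shown sit.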